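Replacing an Amide Group at the Clearance Limit

This account rests on a few compounds, and the source may have more. Where it says the series, first, only, none or still open, it means among the compounds named here.

In an ADME assay (liver) for metabolic stability, with Liver microsome (Homo sapiens) as the target, using microsomes (a lower number here means slower removal, a higher number faster removal of the compound), compound 1 (`Cc1ccc(Oc2cc(C(=O)Nc3cnc(C)cn3)cc3oc(C)cc23)cc1`) gives a measured clearance (47 mL/min/kg). Compound 2 (`Cc1cnc(NC(=O)c2cc(Oc3ncc(C(=O)N(C)C)cn3)c3cc(C)oc3c2)cn1`) returns only a limit of the assay (< 8 mL/min/kg). Compound 3 (`CCN(C)C(=O)c1cnc(Oc2cc(C(=O)Nc3cnc(C)cn3)cc3oc(C)cc23)cn1`) likewise returns only a limit and not a number (< 8 mL/min/kg). Compound 3 therefore stands at the floor of the measured set (the limit of < 8 mL/min/kg in this assay, at which 2 of the 3 values shown sit). Compound 4 (`Cc1cnc(NC(=O)c2cc(Oc3cnc(C(=O)N4CCC4)cn3)c3cc(C)oc3c2)cn1`) has azetidin-1-yl in place of ethyl(methyl)amino on a carbonyl carbon. Going by the values given here, no measured pair of compounds shows this change on its own, so the expectation in this assay is for no step beyond the scatter (a step that the limit leaves unreadable from compound 3 to compound 4). Compound 4 is estimated at 7 mL/min/kg with an expected range from 4 mL/min/kg to 14 mL/min/kg.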

Compound 4, clearance: < 9.3 mL/min/kg
Compound 4 ended at the assay's limit (the forecaster's own chance of this, stated with the estimate: 70%); the middle value lies beyond the limit too.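

In this assay compound 3 gives < 8 mL/min/kg, which is a limit of the assay. Compound 4 gives < 9.3 mL/min/kg, also a limit. No step can be read between compound 3 and compound 4. The compounds shown leave open what size of change in clearance, if any, comes with azetidin-1-yl in place of ethyl(methyl)amino.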